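The compounds below may be only part of what the source reports. "The series", "measured", "known", "first", "only" and "open" are said of these compounds alone.

Of the compounds shown here, three that share one core have been measured in an assay on CHO cells for displacement of a labelled ligand from adenosine receptor A3 (Homo sapiens), read by scintillation counting, tested at 10 uM; on this read-out higher numbers stand for more inhibition at the one concentration tested (going by the name of the read-out) and lower numbers for less inhibition. Compound 1 `CC(C)(C)Cc1csc(N)c1C(=O)c1ccc(Cl)cc1` gives 5%. Compound 2 `CC(C)(C)Cc1c(-c2cccnc2)sc(N)c1C(=O)c1ccc(Cl)cc1` gives 1%, and compound 3 `CC(C)(C)Cc1c(-c2ccc(Cl)cc2)sc(N)c1C(=O)c1ccc(Cl)cc1` gives 1%. On these numbers compound 3 stands level with compound 2 at the digits shown; these two are together the lowest of the three numbers, and the furthest of the three is reached by a number 4 percentage points lower from compound 1 to compound 3 (within the scatter), which is within the scatter.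

Compound 4 `CC(C)(C)Cc1c(/C=C/c2ccc(Cl)cc2)sc(N)c1C(=O)c1ccc(Cl)cc1` differs from compound 3 in one place: 2-(4-chlorophenyl)ethenyl in place of 4-chlorophenyl on an aromatic carbon. The measured steps that bear on this change are the ones at the same ring position: a group entering where hydrogen stood, a number 4 percentage points lower from compound 1 to compound 2 (within the scatter) and a number 4 percentage points lower from compound 1 to compound 3 (within the scatter), and one group replacing another there, no change at the digits printed from compound 2 to compound 3 (within the scatter). None of these moves beyond the scatter, and all three compounds sit close to the floor of the read-out in this assay. The lengthening of the group at this position is therefore expected to give no step beyond the scatter, a number 1 percentage points higher from compound 3 to compound 4 (within the scatter) being the estimate. Compound 4 is expected to show 2% in this assay, with a range from 0% to 12%.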

Compound 4, a percentage reported as inhibition, at one concentration (the size of the read-out at that concentration, not a potency): 11%
Compound 4: the middle estimate sits 9 percentage points below what was measured, and the stated range covers the measured number.
By their numbers in this assay, from the lowest: compounds 2, 3, 1 and 4 (each within the scatter of the next).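

Putting 2-(4-chlorophenyl)ethenyl on the aromatic carbon next to the ring sulfur gives a number 10 percentage points higher from compound 3 to compound 4 (within the scatter) and a number 10 percentage points higher from compound 2 to compound 4 (within the scatter) and a number 6 percentage points higher from compound 1 to compound 4 (within the scatter) in this assay. With its 9 heavy atoms and 1 double bond outside aromatic rings, this group therefore joins pyridin-3-yl and 4-chlorophenyl as a third group at this position whose step stays inside the scatter, so the hydrogen of compound 1 and all three groups remain indistinguishable on this read-out, even with the longer group in place. Nothing at hand accounts for these numbers.

From the compounds shown here alone, whether any group on this carbon can give a step beyond the scatter stays open, for instance an amine, a carboxylic acid, or a longer chain ending in the same 4-chlorophenyl. The compounds shown also all keep the neopentyl, amino and (4-chlorophenyl)carbonyl groups, so they leave open how a cyclohexyl group in place of neopentyl, or an amide in place of the amino group, would read at this one concentration.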